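The source may hold more compounds than are shown below. What is called first, only, known or untested is meant among the compounds shown, and "the series" means these compounds.

In this assay, the measured compounds and their values:
compound 1 `CCOc1ccc(-c2ccc3ncn(-c4cc(OC)c(OC)c(OC)c4)c3c2)cc1` gives 1710 nM;
compound 2 `COc1cc(-n2cnc3ccc(-c4ccc([N+](=O)[O-])cc4)cc32)cc(OC)c1OC` gives 740 nM;
compound 3 `COc1cc(-n2cnc3ccc(-c4cccc(C)c4)cc32)cc(OC)c1OC` gives 360 nM.

In a functional assay on MCF7 cells (Homo sapiens) for antiproliferative activity, read by MTT assay, with a stated time of 72 h (a lower number here means a stronger inhibitor, a higher number a weaker inhibitor), compound 1 stands highest of the three numbers, so it is the weakest inhibitor shown: a 2.3-fold lower number from compound 1 to compound 2 (0.36 log units; beyond the scatter) and a 4.8-fold lower number from compound 1 to compound 3 (0.68 log units; beyond the scatter) both move away from it, and a 2.1-fold lower number from compound 2 to compound 3 (0.31 log units; beyond the scatter) carries on further. Compound 4 `COc1cc(-n2cnc3ccc(-c4cccc(N)c4)cc32)cc(OC)c1OC` differs from compound 1 in one place: 3-aminophenyl in place of 4-ethoxyphenyl on an aromatic carbon. The closest guide is a 4.8-fold lower number from compound 1 to compound 3 (0.68 log units; beyond the scatter), where another 3-substituted phenyl replaced the same 4-ethoxyphenyl; a 2.3-fold lower number from compound 1 to compound 2 (0.36 log units; beyond the scatter) also shows that leaving the ethoxy gave a lower number. A modest step down is therefore expected, about a 3.4-fold lower number from compound 1 to compound 4 (0.53 log units; beyond the scatter). Compound 4 is estimated at 500 nM, likely between 200 nM and 1400 nM.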

Compound 4, half-maximal inhibitory concentration: 180 nM
The estimate for compound 4 lay 2.8-fold (0.44 log units) above the measured number, and the stated range ends above it.
By their numbers in this assay, from the lowest: compounds 4 and 3 (each within the scatter of the next); then compound 2; then compound 1.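

In this assay, 3-aminophenyl in place of 4-ethoxyphenyl gives a 9.5-fold lower number from compound 1 to compound 4 (0.98 log units; beyond the scatter) and in place of 4-nitrophenyl gives a 4.1-fold lower number from compound 2 to compound 4 (0.61 log units; beyond the scatter), so this change reaches a lower number than either of those groups. Amino in place of methyl gives a 2.0-fold lower number from compound 3 to compound 4 (0.30 log units; within the scatter), so the two groups cannot be told apart here. Nothing measured here explains these steps.

As far as these compounds go, whether 4-aminophenyl would match 3-aminophenyl remains open. So does how a hydroxyl or a carboxylic acid would compare with amino on the same ring.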